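Adding Propargyloxy to the Stronger of Two Inhibitors

A few compounds are considered here, and "the series" means these few. Any claim that something is new, unique, unknown or untested is made for them only; others in the source may bear on it.

In a functional assay on the whole organism for inhibition, with Echinochloa esculenta as the target (a lower number here means a stronger inhibitor, a higher number a weaker inhibitor), compound 1 `Cc1cc(Cl)ccc1/N=c1\sc(=S)n2n1CCCC2` gives 2880 nM, while compound 2 `Fc1cc(Cl)ccc1/N=c1\sc(=S)n2n1CCCC2` gives 158 nM. Compound 2 therefore holds the lower of the two numbers and is the stronger inhibitor of this pair. Among the compounds with values here, the single measured step, an 18-fold lower number from compound 1 to compound 2 (1.26 log units; beyond the scatter), comes from fluoro in place of methyl on an aromatic carbon.

Compound 3 `C#CCOc1cc(/N=c2\sc(=S)n3n2CCCC3)c(F)cc1Cl` keeps everything in compound 2 except for one further change to that aromatic ring: propargyloxy in place of hydrogen on an aromatic carbon. In words, this is propargyloxy in place of hydrogen on an aromatic carbon. Within the data shown here, no measured step involves this group, so the data give no direct size for the change. The step of an 18-fold lower number from compound 1 to compound 2 (1.26 log units; beyond the scatter) does show that one substitution on this ring can move the number a long way in this assay. A step beyond the scatter is therefore expected here, with a lower number as the likelier direction, although this evidence is thin. The expected step is a 4.0-fold lower number from compound 2 to compound 3 (0.60 log units; beyond the scatter). For compound 3, the estimated value is 40 nM, within an expected range of 5 nM to 300 nM.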

Compound 3, half-maximal inhibitory concentration: 5.89 nM
The estimate for compound 3 lay 6.8-fold (0.83 log units) above the measured number; the range from low to high includes it.
By their numbers in this assay, from the lowest: compound 3; then compound 2; then compound 1.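

Placing propargyloxy on the aromatic carbon that is ortho to a chloro group and para to a fluoro group gives a 27-fold lower number from compound 2 to compound 3 (1.43 log units; beyond the scatter) in this assay. This carbon carries only hydrogen in compound 2, and the result shows that adding a chain here can strengthen inhibition rather than weaken it. Within the data shown here, until now, the only measured change on this ring was the replacement of one group by another at a different carbon, an 18-fold lower number from compound 1 to compound 2 (1.26 log units; beyond the scatter), so a second site on the same ring is now known to move the number well beyond the scatter.

No measurement offered here explains why the number falls. The compounds shown do not separate the contribution of the oxygen from that of the triple bond, so a methoxy group or a saturated propoxy chain on the same carbon would be the natural comparison. On these data alone, it also remains open whether propargyloxy would give a similar step with methyl on the ring in place of fluoro, or whether a longer chain with a triple bond would be tolerated here.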